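Trifluoromethoxy in place of hydroxy: a cytotoxicity step

This account rests on a few compounds, and the source may have more. Where it says the series, first, only, none or still open, it means among the compounds named here.

Compound 1, `CC(=O)c1cccc(-c2ccc(C(=O)N(Cc3cccc(OCCCCCC(=O)O)c3)C(C)C)cc2)c1`: in an ADME assay on BJ cells (Homo sapiens) for cytotoxicity, read by CellTiter-Glo and resazurin assay, with a stated time of 72 h (a lower number here means that less compound is needed, a higher number that more compound is needed for the effect), compound 1 gives > 26000 nM, which is a limit of the assay rather than a number.
Compound 2, `CC(C)N(Cc1cccc(OCCCCCC(=O)O)c1)C(=O)c1ccc(-c2cccc(O)c2)cc1`: in this assay compound 2 gives > 26000 nM, again a limit and not a number.

For the measured compounds named here, the single measured step, a step that the two limits leave unreadable from compound 1 to compound 2, cannot be read in size or direction: both values sit at the limit described by the limit of > 26000 nM in this assay, at which 2 of the 2 values shown sit. Compound 2 therefore stands at the limit of this assay, and nothing more precise can be said of its position from the numbers shown.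

Compound 3, `CC(C)N(Cc1cccc(OCCCCCC(=O)O)c1)C(=O)c1ccc(-c2cccc(OC(F)(F)F)c2)cc1`, differs from compound 2 by trifluoromethyl in place of hydrogen on an oxygen on an aromatic ring. Going by the values given here, no measured step bears on this change in a readable way, as the one step available is itself unreadable. The expectation for compound 3 in this assay is therefore that it, too, reaches the limit, and the step that the limit leaves unreadable from compound 2 to compound 3 is expected to stay within the scatter. Compound 3 is estimated at 40000 nM. For compound 3 the expected range runs from 15000 nM to 100000 nM.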

Compound 3, half-maximal effective concentration: > 26000 nM
Compound 3: no number, only a limit; the forecaster's own chance of this, stated with the estimate: 80%; the middle value lies beyond the limit too.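

In this assay compound 3 gives > 26000 nM as a limit and not a number. For the compounds shown here, no step among compound 1, compound 2 and compound 3 can be read in size or direction, because all three values sit at one limit: the limit of > 26000 nM in this assay, at which 3 of the 3 values shown sit. The compounds shown leave open whether the acetyl, hydroxy and trifluoromethoxy compounds differ at all in this read-out.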